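Trimming the trimethoxyphenyl in the chalcone series

A few compounds are considered here, and "the series" means these few. Any claim that something is new, unique, unknown or untested is made for them only; others in the source may bear on it.

Going by the values given here, compound 1 `COc1cc(/C=C/C(=O)c2cc(-c3cc(OC)c(OC)c(OC)c3)n3nc(-c4ccccc4)cc3n2)cc(OC)c1OC` gives 25900 nM in a functional assay on A549 cells (Homo sapiens) for antiproliferative activity, read by MTT assay, with a stated time of 24 h (on this read-out lower numbers stand for stronger inhibition and higher numbers for weaker inhibition), the highest of the three numbers so far. Compound 2 `COc1ccc(C(=O)/C=C/c2cc(-c3cc(OC)c(OC)c(OC)c3)n3nc(-c4ccccc4)cc3n2)cc1OC` gives 17800 nM, which lies within the scatter of compound 1. Compound 3 `COc1ccc(-c2cc(/C=C/C(=O)c3ccc(OC)c(OC)c3)nc3cc(-c4ccccc4)nn23)cc1` gives 7400 nM, a lower number than compound 1 by a margin beyond the scatter. Among the compounds with values here, the one single-point step in hand is a 2.4-fold lower number from compound 2 to compound 3 (0.38 log units; beyond the scatter), where the aryl group on the shared core is pared down.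

Compound 4 `COc1ccc(-c2cc(C(=O)/C=C/c3cc(OC)c(OC)c(OC)c3)nc3cc(-c4ccccc4)nn23)cc1OC` differs from compound 1 by hydrogen in place of methoxy on an aromatic carbon. This also pares down the aryl group on the core, though less deeply than the step from compound 2 to compound 3, so a smaller version of that move in this assay is the natural expectation, toward a lower number. Compound 4 is therefore expected to give 15000 nM, with a range of 7000 nM to 35000 nM, which is the estimated step of a 1.7-fold lower number from compound 1 to compound 4 (0.24 log units; within the scatter). The expectation rests on a single step and should be held loosely.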

Compound 4, half-maximal inhibitory concentration: 15400 nM
For compound 4 the middle estimate is 1.0-fold (0.01 log units) below the measured one; measured number inside the range.
By their numbers in this assay, from the lowest: compound 3; then compounds 4, 2 and 1 (each within the scatter of the next).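

Going from 3,4,5-trimethoxyphenyl to 3,4-dimethoxyphenyl on the core gives a 1.7-fold lower number from compound 1 to compound 4 (0.23 log units; within the scatter) in this assay, so losing this one methoxy group does not separate the two compounds on this read-out. Going by these compounds alone, the deeper trim to 4-methoxyphenyl, a 2.4-fold lower number from compound 2 to compound 3 (0.38 log units; beyond the scatter), is the only step so far that lies beyond the scatter, so on these few compounds a single methoxy removal at this aryl group is not enough to register. No measurement in hand bears on why the number responds in this way.

Still open, on these data alone, is whether the 3,4-dimethoxyphenyl group tolerates something other than methoxy at the vacated place. A hydroxyl, an amine or a longer chain such as ethoxy on that aromatic carbon would test how much this position matters in this assay.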